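The compounds below may be only part of what the source reports. "The series", "measured", "known", "first", "only" and "open" are said of these compounds alone.

Measured so far:
compound 1 `Cc1ccc(-c2cc(C)cc(C(=O)Nc3nn[nH]n3)n2)cc1` — 100%
compound 2 `CCc1cc(C(=O)Nc2nn[nH]n2)nc(-c2ccccc2)c1` — 53%
compound 3 `CCCc1cc(C(=O)Nc2nn[nH]n2)nc(-c2ccc(C)cc2)c1` — 50%

Not yet measured: compound 4 `CCCCc1cc(C(=O)Nc2nn[nH]n2)nc(-c2ccccc2)c1`.

All three numbers come from a functional assay on the whole organism with Rattus norvegicus as the target, at a dose of 3 mg/kg by the oral route; on this read-out lower numbers stand for a weaker effect and higher numbers for a stronger effect at the one dose given. In this assay compound 1 gives 100%, compound 2 gives 53% and compound 3 gives 50%; the values of compound 2 and compound 3 lie within the scatter of each other, so nothing is said of their order.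

One step is fully measured. From compound 1 to compound 3 the change is ethyl in place of hydrogen on a saturated chain carbon bound to an aromatic carbon, and it reads a number 50 percentage points lower from compound 1 to compound 3 (beyond the scatter).

Compound 2 and compound 1 share the same atoms joined differently; the difference between the two cores is not broken down here.

Compound 4 stands to compound 2 as compound 3 stands to compound 1 in kind: ethyl in place of hydrogen on a saturated chain carbon, two bonds along the chain from an aromatic carbon. It is the same kind of change, not the same: in the measured pair the entering group sits on a saturated chain carbon bound to an aromatic carbon, whereas here it sits on a saturated chain carbon two bonds along the chain from an aromatic carbon, and the chain grows from ethyl to butyl rather than from methyl to propyl.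

The expectation rests on one measured step only, so it is loosely held. For the measured compounds named here, because compound 2 starts from 53% and the only related step, a number 50 percentage points lower from compound 1 to compound 3 (beyond the scatter), is a large drop, a further fall is expected, though the different place leaves its size uncertain: the estimated step is a number 28 percentage points lower from compound 2 to compound 4 (beyond the scatter). Compound 4 is therefore expected to give about 25% in this assay, between 5% and 50%.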

Compound 4, a percentage reported as inhibition, in the whole organism at one dose (the size of the read-out at that dose, not a potency): 71%
The estimate for compound 4 lay 46 percentage points below the measured number, outside the stated range (above it).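

In this assay the new step reads a number 18 percentage points higher from compound 2 to compound 4 (beyond the scatter) and does not repeat the earlier fall. Ethyl in place of hydrogen therefore cannot be carried as a fixed increment between these two cores, and the same kind of change runs in opposite directions on them: the same change on two cores in this assay, a number 50 percentage points lower (beyond the scatter) from compound 1 to compound 3 and a number 18 percentage points higher (beyond the scatter) from compound 2 to compound 4, 68 percentage points apart, beyond the scatter of two such steps. This shows that the outcome of the change in this series depends on the setting in which it is made, but with one pair on each core it does not show whether the core itself or the starting chain decides the direction, as the pairs differ in both, one going from methyl to propyl and the other from ethyl to butyl.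

The compounds shown leave open whether a chain longer than butyl, a branched chain such as isopropyl, or a chain ending in an amine or a carboxylic acid would keep or lose the reading on the core of compound 2. Also open, on these data alone, is whether the same directions would hold at other doses, as each number here gives the size of the effect at a single oral dose and not a potency.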